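An ester replaces the acid on the amine nitrogen

This account rests on a few compounds, and the source may have more. Where it says the series, first, only, none or still open, it means among the compounds named here.

In a functional assay on MCF7 cells (Homo sapiens) for inhibition, read by MTT assay, with a stated time of 3 days (on this read-out lower numbers stand for stronger inhibition and higher numbers for weaker inhibition), compound 1 (`COc1cc(-c2nc3ccccc3s2)ccc1OCC(=O)NNC(=O)CN[C@@H](CS(=O)(=O)O)C(=O)O`) gives 1870 nM and compound 2 (`COc1cc(-c2nc3ccccc3s2)ccc1OCC(=O)NNC(=O)CN[C@@H](CCSC)C(=O)O`) gives 1950 nM so compound 2 stands level with compound 1. Compound 3 (`CCOC(=O)[C@H](NCC(=O)NNC(=O)COc1ccc(-c2nc3ccccc3s2)cc1OC)[C@@H](C)CC`) differs from compound 2 on an amine nitrogen (1-(ethoxycarbonyl)-2-methylbutyl in place of 1-carboxy-3-(methylsulfanyl)propyl on an amine nitrogen) where 1-(ethoxycarbonyl)-2-methylbutyl stands in place of 1-carboxy-3-(methylsulfanyl)propyl. Going by the values given here, only one measured step bears on this (a 1.0-fold higher number from compound 1 to compound 2 (0.02 log units; within the scatter)) and it lies within the scatter, though it tests no ester. The expected change therefore stays inside the scatter (a 1.1-fold lower number from compound 2 to compound 3 (0.06 log units; within the scatter)). In this assay compound 3 is estimated at 1700 nM (expected range 600 nM to 5000 nM).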

Compound 3, half-maximal inhibitory concentration: 2900 nM
The estimate for compound 3 lay 1.7-fold (0.23 log units) below the measured number, and the stated range covers the measured number.
By their numbers in this assay, from the lowest: compounds 1, 2 and 3 (each within the scatter of the next).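

In this assay, placing 1-(ethoxycarbonyl)-2-methylbutyl on the amine nitrogen gives a 1.5-fold higher number from compound 2 to compound 3 (0.17 log units; within the scatter) and a 1.6-fold higher number from compound 1 to compound 3 (0.19 log units; within the scatter). A substituent with an ethyl ester and no free carboxylic acid is therefore not separated from the two acids at this position. No measurement shown accounts for this result. The change alters both the ester and the side chain, so the compounds shown leave open what each contributes alone. A free carboxylic acid on the same 2-methylbutyl chain, or an amine on the side chain, remains to be read.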